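The source may report more compounds than this note shows. Statements on the series, on what has been measured and on what is new or still open speak of the compounds shown alone.

Compound 1 `CC1(C)C=C(n2ccccc2=O)c2cc(C(=O)c3ccccc3)ccc2O1` is one of three compounds examined in a functional assay (aorta) with Rattus norvegicus as the target (a higher number here means a more potent compound, by a factor of ten per unit of this negative logarithm, a lower number a less potent compound), where compound 1 gives 6.61. This is the second highest of the three numbers. Within the data shown here, compound 2 `Cc1ccccc1C(=O)c1ccc2c(c1)C(n1ccccc1=O)=CC(C)(C)O2` gives 6.83; the single step of one change, a number 0.22 log units higher from compound 1 to compound 2 (within the scatter), lies within the scatter. Compound 3 `CC1(C)C=C(n2ccccc2=O)c2cc(OC(=O)Nc3ccccc3C(F)(F)F)ccc2O1`, which carries no benzoyl, gives 5.58, a number well beyond the scatter below compound 1.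

The next compound, compound 4 `CC1(C)C=C(n2ccccc2=O)c2cc(OS(=O)(=O)F)ccc2O1`, differs from compound 1 in one place: (fluorosulfonyl)oxy in place of benzoyl on an aromatic carbon. Among the measured compounds shown here, no measured step concerns this kind of exchange. For the measured compounds named here, the only step in hand, from compound 1 to compound 2, alters the benzoyl and changes little, so it says nothing about removing it entirely. Going by the values given here, the only hint is compound 3, which without the benzoyl gives a lower number, but that comparison is not a single-change step. A drop is therefore expected, though with wide uncertainty, and the step of a number 0.81 log units lower from compound 1 to compound 4 (beyond the scatter) is the estimated outcome. Compound 4 is expected to give about 5.8, between 5 and 6.6.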

Compound 4, logarithm of the reciprocal of the active concentration, log(1/C): 7.95
Compound 4: middle estimate off by 2.15 log units, on the low side; measured number outside the range, above it.
By their numbers in this assay, from the lowest: compound 3; then compounds 1 and 2 (each within the scatter of the next); then compound 4.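

In this assay, the benzoyl group of compound 1 proves dispensable at this aromatic carbon: a (fluorosulfonyl)oxy group, which carries no ring, gives a number 1.34 log units higher from compound 1 to compound 4 (beyond the scatter), a large rise rather than a loss. Starting instead from the (2-methylphenyl)carbonyl group, the same kind of exchange gives a number 1.12 log units higher from compound 2 to compound 4 (beyond the scatter), so the rise is seen with both aromatic ketone groups and not with just one of them. Nothing available here explains why this exchange raises the number.

From the compounds shown here alone, it remains open whether the rise needs the fluorine and sulfur of the new group, which a methanesulfonyloxy or acetoxy group at the same carbon could test. An amine or a carboxylic acid there would show how widely this position accepts other groups.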